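From isopropyl to 3-chlorophenyl on the shared core

The source may hold more compounds than are shown below. What is called first, only, known or untested is meant among the compounds shown, and "the series" means these compounds.

In a functional assay on HCT-116 cells (Homo sapiens) for antiproliferative activity, read by MTT assay, with a stated time of 72 h (on this read-out lower numbers stand for stronger inhibition and higher numbers for weaker inhibition), compound 3 (`CC(C)c1cccc(NC(=O)CCc2cccc3c2B(O)OC3)c1`) gives 1600 nM and holds the lowest number shown. Compound 1 (`O=C(CCc1cccc2c1B(O)OC2)Nc1ccc(Br)cc1`) comes nearest at 46000 nM on this read-out, a gap beyond the scatter. For compound 2 (`CCOC(=O)c1ccc(NC(=O)CCc2cccc3c2B(O)OC3)cc1`) the assay returns a limit, > 100000 nM and not a number.

Compound 4 (`O=C(CCc1cccc2c1B(O)OC2)Nc1cccc(-c2cccc(Cl)c2)c1`) differs from compound 3 by 3-chlorophenyl in place of isopropyl on an aromatic carbon with 3-chlorophenyl in place of isopropyl on an aromatic carbon, meta to a large group. For the measured compounds named here, the one measured step, an at least 2.1-fold higher number from compound 1 to compound 2 (0.33 log units; beyond the scatter) for ethoxycarbonyl in place of bromo on an aromatic carbon, involves other groups and bears on this change only indirectly. That step and the gap between the values of compound 3 and compound 1 show that swapping such groups can move the number beyond the scatter, but neither fixes a direction here.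

Compound 3 at 1600 nM already sits lowest of the numbers, so a moderate rise in this assay is expected rather than a fall. The expected change is a 1.9-fold higher number from compound 3 to compound 4 (0.27 log units; within the scatter) with a wide margin either way. Compound 4 is estimated at 3000 nM with an expected range from 400 nM to 25000 nM in this estimate.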

Compound 4, half-maximal inhibitory concentration: 350 nM
For compound 4 the middle estimate is 8.6-fold (0.93 log units) above the measured one; the measured number lies below the stated range.
By their numbers in this assay, from the lowest: compound 4; then compound 3; then compound 1. At a limit, above all of these: compound 2.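

In this assay, 3-chlorophenyl in place of isopropyl on an aromatic carbon, meta to a large group, gives a 4.6-fold lower number from compound 3 to compound 4 (0.66 log units; beyond the scatter). The position therefore accepts a change from 3 heavy atoms to 7 heavy atoms, including a six-membered aromatic ring of carbon only, and the number falls rather than rises. For the compounds shown here, the earlier values showed only that changing groups on the aromatic ring of the amide could move the number, and the one earlier step concerned other groups, whereas this step gives a direction for this position and this change. Nothing measured in the data shown accounts for the fall.

The compounds shown leave open whether the chlorine contributes to this step, which a plain phenyl group in the same place would test, and whether an aromatic ring is needed at all, which a longer alkyl chain there would test. They also leave open how an amine or a carboxylic acid on the entering ring would read in this assay, and whether a pyridine ring would serve in place of the chlorophenyl ring.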